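Nitro substitution on a shared indole-benzofuran core

The source may hold more compounds than are shown below. What is called first, only, known or untested is meant among the compounds shown, and "the series" means these compounds.

Measured so far:
compound 1 `O=[N+]([O-])c1ccc2[nH]cc(C(c3ccccc3)c3cc4ccccc4o3)c2c1` – 40400 nM
compound 2 `Clc1ccc2oc(C(c3ccccc3)c3c[nH]c4ccccc34)cc2c1` – 58000 nM
compound 3 `Cc1[nH]c2ccccc2c1C(c1ccccc1)c1cc2cc(Cl)ccc2o1` – 47500 nM

In a functional assay on SiHa cells (Homo sapiens) for cytotoxicity (a lower number here means a stronger inhibitor, a higher number a weaker inhibitor), the three measured compounds give numbers that all lie within the usual scatter of one another. Among the measured compounds shown here, compound 2 therefore stands beside the others rather than apart from them: the only single-point step recorded, a 1.2-fold lower number from compound 2 to compound 3 (0.09 log units; within the scatter), adds a methyl group and changes nothing beyond the scatter, and the gap between compound 2 and compound 1 is likewise within the scatter.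

Compound 4 `O=[N+]([O-])c1ccc2[nH]cc(C(c3ccccc3)c3cc4cc(Cl)ccc4o3)c2c1` is derived from compound 2 by nitro in place of hydrogen on an aromatic carbon. For the measured compounds named here, no measured step covers exactly this change. The closest evidence is indirect: compound 1, which also carries a nitro group on its core, gives 40400 nM in this assay, a number within the scatter of compound 2. Going by the values given here, the one step that is recorded, from compound 2 to compound 3, also stayed within the scatter. On this basis the expectation for compound 4 is no movement beyond the scatter, in either direction.

Compound 4 is thus estimated to give 50000 nM, with a range from 22000 nM to 110000 nM, which corresponds to an expected step of a 1.2-fold lower number from compound 2 to compound 4 (0.06 log units; within the scatter).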

Compound 4, half-maximal inhibitory concentration: > 100000 nM
Compound 4 was reported as a limit (the forecaster's own chance of this, stated with the estimate: 10%); middle value at least 2.0-fold (0.30 log units) from the limit.
By their numbers in this assay, from the lowest: compounds 1, 3 and 2 (each within the scatter of the next). At a limit, above all of these: compound 4.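

In this assay compound 4 is reported at a limit of the assay, so its step can be read only as a floor: the limit of > 100000 nM in this assay, at which 1 of the 4 values shown sits.

With nitro in place of hydrogen on an aromatic carbon of the six-membered carbon ring, the change shows an at least 1.7-fold higher number from compound 2 to compound 4 (0.23 log units; that floor lies within the scatter), so this floor alone does not establish a real loss, though the true size of the step may be larger. The chloro change is clearer, with an at least 2.4-fold higher number from compound 1 to compound 4 (0.39 log units; beyond the scatter), and it gives the first step beyond the scatter among the compounds shown, whereas the earlier recorded methyl change, a 1.2-fold lower number from compound 2 to compound 3 (0.09 log units; within the scatter), had shown none; with nitro on the core, chloro in place of hydrogen therefore gives a weaker inhibitor.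

The compounds shown leave open how far past the limit compound 4 really lies, and so how large either step is. Also open, going by these compounds, is whether an amine or a carboxylic acid in place of the nitro group, on the same carbon and with the chloro group kept, would bring the number back within reach of this assay.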